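Aryl swaps in the cytotoxicity series: compound 3 to compound 4

The source may report more compounds than this note shows. Statements on the series, on what has been measured and on what is new or still open speak of the compounds shown alone.

Values in a functional assay on SW-620 cells (Homo sapiens) for cytotoxicity, read by MTT assay, with a stated time of 72 h; a higher number here means a weaker inhibitor, a lower number a stronger inhibitor:
compound 1 `COc1ccc(/C=C2\CCC/C(=C\c3ccccc3Br)C2=O)cc1OC`: 5300 nM
compound 2 `COc1ccccc1/C=C1\CCC/C(=C\c2ccc(OC)c(OC)c2)C1=O`: 7800 nM
compound 3 `COc1ccc(/C=C2\CCC/C(=C\c3ccc(OC)c(OC)c3)C2=O)cc1`: 6600 nM

Compound 3 does not stand apart from the other two measured compounds. Its steps are a 1.2-fold higher number from compound 1 to compound 3 (0.10 log units; within the scatter) and a 1.2-fold lower number from compound 2 to compound 3 (0.07 log units; within the scatter), and the remaining pair gives a 1.5-fold higher number from compound 1 to compound 2 (0.17 log units; within the scatter). The three values therefore form a single group, with no ranking among them.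

The next compound is compound 4 `COc1ccc(/C=C2\CCC/C(=C\c3ccc(Cl)c(Cl)c3)C2=O)cc1OC`. Its difference from compound 3 is 3,4-dichlorophenyl in place of 4-methoxyphenyl on a double-bonded chain carbon bound to a double-bonded ring carbon.

Within the data shown here, no measured compound carries 3,4-dichlorophenyl, so this exact change has no direct precedent. The nearest evidence is the replacement of 2-bromophenyl by 4-methoxyphenyl, seen as a 1.2-fold higher number from compound 1 to compound 3 (0.10 log units; within the scatter), and the replacement of 2-methoxyphenyl by 4-methoxyphenyl, seen as a 1.2-fold lower number from compound 2 to compound 3 (0.07 log units; within the scatter). Neither step gives a direction for the new change. In this assay, no step beyond the scatter is therefore expected, although three compounds are a thin basis for this expectation.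

The expected step is a 1.2-fold lower number from compound 3 to compound 4 (0.08 log units; within the scatter). For compound 4 the estimated value is 5500 nM, with an expected range of 2500 nM to 12000 nM.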

Compound 4, half-maximal inhibitory concentration: 4000 nM
Estimate against measurement, compound 4: 1.4-fold (0.14 log units) above; the range from low to high includes it.
By their numbers in this assay, from the lowest: compounds 4, 1, 3 and 2 (each within the scatter of the next).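

In this assay, the position on the double-bonded chain carbon bound to a double-bonded ring carbon also accepts 3,4-dichlorophenyl, with the steps reading a 1.7-fold lower number from compound 3 to compound 4 (0.22 log units; within the scatter), a 2.0-fold lower number from compound 2 to compound 4 (0.29 log units; within the scatter) and a 1.3-fold lower number from compound 1 to compound 4 (0.12 log units; within the scatter). Of the groups shown at this position, only 3,4-dichlorophenyl carries two chlorine atoms, and exchanging the oxygen-bearing 4-methoxyphenyl for it gives no step beyond the scatter, so the four compounds remain a single group with no ranking among them. No measurement is available that bears on why these values lie so close together.

Every group shown at this position is a phenyl ring bearing methoxy or halogen, so it remains open whether any change here can produce a step beyond the scatter; an amine or a carboxylic acid on that phenyl ring, or a longer chain in its place, would test this. On these data alone, the other aryl group stays the same in all four compounds, so what a change at that end of the shared core would do also remains open.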